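From 2-hydroxyethyl to cyclopropyl on an amide-type nitrogen

The source may report more compounds than this note shows. Statements on the series, on what has been measured and on what is new or still open speak of the compounds shown alone.

In a physicochemical assay for solubility (on this read-out lower numbers stand for lower solubility and higher numbers for higher solubility), compound 1 (`CNC(=O)c1cc(C(=O)NCCO)n([C@@H](C)c2ccccc2)n1`) gives >= 139 ug/mL as a limit, not a number. Compound 2 (`CNC(=O)c1cc(C(=O)NC)n([C@@H](C)c2ccccc2)n1`) gives >= 88 ug/mL as a limit too. Compound 3 (`CNC(=O)c1cc(C(=O)N[C@H]2CC[C@H](O)CC2)c([C@@H](C)c2ccccc2)o1`) likewise gives >= 184 ug/mL as a limit. Compound 1 therefore has no measured number to place it, and neither do the two compounds beside it.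

Compound 4 (`CNC(=O)c1cc(C(=O)NC2CC2)n([C@@H](C)c2ccccc2)n1`) keeps the core of compound 1 and carries cyclopropyl in place of 2-hydroxyethyl on an amide-type nitrogen. Within the data shown here, the one measured step that touches this 2-hydroxyethyl group (a step that the two limits leave unreadable from compound 1 to compound 2) has no readable size, so it gives neither a size nor a direction for the change.

The expectation therefore rests on compound 1 at >= 139 ug/mL as a limit. No step beyond the usual scatter is expected in this assay, and the estimated change is an at least 1.3-fold lower number from compound 1 to compound 4 (0.14 log units; that floor lies within the scatter) on that reading. For compound 4 the estimate is 100 ug/mL with an expected range from 40 ug/mL to 250 ug/mL in this read-out.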

Compound 4, solubility: >= 165 ug/mL
Compound 4 ended at the assay's limit; the forecaster's own chance of this, stated with the estimate: 60%; middle value at least 1.6-fold (0.21 log units) away from the limit.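

In this assay compound 4 gives >= 165 ug/mL, a limit and not a number. With compound 1 and compound 2 also standing only as limits, neither step to compound 4 can be read. The compounds shown leave open whether cyclopropyl, 2-hydroxyethyl or methyl on the amide-type nitrogen shifts this read-out at all, and in which direction.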